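A few compounds are considered here, and "the series" means these few. Any claim that something is new, unique, unknown or untested is made for them only; others in the source may bear on it.

Measured so far:
- compound 1 `O=C(Oc1cccc2ccccc12)c1cccc([N+](=O)[O-])c1` — in an assay on isolated protein for inhibition of Polyunsaturated fatty acid 5-lipoxygenase (Homo sapiens), read by fluorescence, with a stated time of 10 min (a higher number here means a weaker inhibitor, a lower number a stronger inhibitor), compound 1 gives 7100 nM.
- compound 2 `O=C(O)c1cccc(C(=O)OCc2ccccc2)c1` — compound 2 gives > 50000 nM, which is a limit of this assay and not a number.

Compound 1 thus holds the only number shown; the other value sits at the limit, (the limit of > 50000 nM in this assay, at which 1 of the 2 values shown sits). Within the data shown here, no pair of measured compounds differs in a single place, so no measured step is available.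

Compound 3 `O=C(O)c1cccc(C(=O)Oc2cccc3ccccc23)c1` differs from compound 1 by carboxy in place of nitro on an aromatic carbon. Compound 2, which also carries a carboxy, gives only the limit > 50000 nM in this assay. For compound 3 a step of a 2.5-fold higher number from compound 1 to compound 3 (0.40 log units; beyond the scatter) toward weaker inhibition is expected, beyond the scatter. The estimate for compound 3 is 18000 nM, between 5000 nM and 60000 nM.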

Compound 3, half-maximal inhibitory concentration: > 50000 nM
Compound 3: only a limit was reported; the forecaster's own chance of this, stated with the estimate: 35%; middle value at least 2.7-fold (0.44 log units) away from the limit.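

On the core of compound 1, the position meta to a large group is sensitive to this change: carboxy in place of nitro gives an at least 7.0-fold higher number from compound 1 to compound 3 (0.84 log units; beyond the scatter). The value for compound 3 is a limit of the assay and not a number, so the step has a lower bound only. Compound 3 now stands with compound 2, the other carboxy compound shown, and neither gives a number: the limit of > 50000 nM in this assay, at which 2 of the 3 values shown sit.

From the compounds shown here alone, whether the loss comes from gaining carboxy or from losing nitro stays open. Going by these compounds, how an amine, a nitrile or a methyl ester at this place would read in this assay also stays open.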